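The compounds below may be only part of what the source reports. "The series", "measured", "known", "first", "only" and "open" are said of these compounds alone.

Compound 1 `CC(=O)c1cc(C(=O)c2ccccc2)c(=O)[nH]c1C` and compound 2 `O=C1CCCc2[nH]c(=O)c(C(=O)c3ccccc3)cc21` were both tested in an assay on isolated protein for inhibition of 3',5'-cyclic-AMP phosphodiesterase 4A (Cavia porcellus), read by cAMP accumulation, tested at 50 uM; on this read-out higher numbers stand for a stronger effect at the one concentration tested and lower numbers for a weaker effect. There compound 1 gives 4.35%, and compound 2 gives 4.3%; the two numbers lie within the scatter of each other, so neither can be set apart from the other. Compound 3 `CC(=O)c1cc(C(=O)C(C)(C)C)c(=O)[nH]c1C` differs from compound 1 by tert-butyl in place of phenyl on a carbonyl carbon. Going by the values given here, no measured pair shows what this change does in this assay. Because compound 1 gives 4.35% in this assay, the expected step is a number 0.7 percentage points higher from compound 1 to compound 3 (within the scatter), not beyond the scatter in either direction. Compound 3 is therefore estimated at 5%, with a range from 0% to 20%.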

Compound 3, a percentage reported as inhibition, at one concentration (the size of the read-out at that concentration, not a potency): 2.15%
Beside the measured number, compound 3's estimate is 2.9 percentage points above it, and the stated range covers the measured number.
By their numbers in this assay, from the lowest: compounds 3, 2 and 1 (each within the scatter of the next).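

In this assay tert-butyl in place of phenyl on a carbonyl carbon gives a number 2.2 percentage points lower from compound 1 to compound 3 (within the scatter) and so shows that, at this position, an aromatic ring can give way to a group without a ring with no step beyond the scatter. With all the numbers this small at the one concentration tested, the result does not show how much this position can matter. No measurement at hand bears on the result. The compounds shown leave open whether an amine, a carboxylic acid or a longer chain on this carbonyl carbon would move the number beyond the scatter.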